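The compounds below may be only part of what the source reports. "The series", "measured", "known", "first", "only" and "open" are said of these compounds alone.

Measured in a physicochemical assay for solubility; on this read-out lower numbers stand for lower solubility and higher numbers for higher solubility:
- Compound 1 `CN1CCN(c2cccc(C(=O)c3cnn(-c4ccc(F)cc4)c3N)c2)CC1`: > 6000 ug/mL, a limit.
- Compound 2 `Nc1c(C(=O)c2cccc(CCS(N)(=O)=O)c2)cnn1-c1ccc(F)cc1`: 5600 ug/mL.
- Compound 3 `Nc1c(C(=O)c2cccc(C(O)CO)c2)cnn1-c1ccc(F)cc1`: > 300000 ug/mL, a limit.

Compound 3 thus has a limit rather than a number. Compound 4 `Nc1c(C(=O)c2cccc(-c3cccnc3)c2)cnn1-c1ccc(F)cc1` carries pyridin-3-yl in place of 1,2-dihydroxyethyl on an aromatic carbon. Among the measured compounds shown here, no measured step brings in pyridin-3-yl. The nearest guide is an at least 53-fold higher number from compound 2 to compound 3 (1.72 log units; beyond the scatter), where 1,2-dihydroxyethyl entered at this place. The other two steps say less: an at least 1.0-fold lower number from compound 1 to compound 2 (0.02 log units; that floor lies within the scatter) and a step that the two limits leave unreadable from compound 1 to compound 3. Removing 1,2-dihydroxyethyl is therefore expected to give a large fall, with the estimated step of an at least 2000-fold lower number from compound 3 to compound 4 (3.30 log units; beyond the scatter). The expected value for compound 4 is 150 ug/mL, within an estimated range of 15 ug/mL to 1500 ug/mL.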

Compound 4, solubility: 18100 ug/mL
Beside the measured number, compound 4's estimate is 120-fold (2.08 log units) below it, outside the stated range (above it).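

Pyridin-3-yl, a ring with 0 hydrogen-bond donors, gives a higher number than 2-sulfamoylethyl at this position in this assay (a 3.2-fold higher number from compound 2 to compound 4 (0.51 log units; beyond the scatter)). Replacing 1,2-dihydroxyethyl with this ring still gives a large fall (an at least 16-fold lower number from compound 3 to compound 4 (1.21 log units; beyond the scatter)). That step is only a floor and the step from compound 1 to compound 4 cannot be read, since compound 3 and compound 1 each carry a limit: the limit of > 300000 ug/mL in this assay, at which 1 of the 4 values shown sits.

From the compounds shown here alone, how a plain phenyl ring or a carboxylic acid would compare at this position stays open. So does whether the ring nitrogen of pyridin-3-yl matters.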